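Bromo in Place of Benzoyl: What Compound 3 Might Show

This account rests on a few compounds, and the source may have more. Where it says the series, first, only, none or still open, it means among the compounds named here.

Measured compounds:
compound 1 `C=CCc1ccc(OCc2cn(-c3ccccc3CO)nn2)c(O)c1`: 39.6%
compound 2 `C=CCc1ccc(OCc2cn(-c3ccc(C(=O)c4ccccc4)cc3)nn2)c(O)c1`: 40.1%

In a functional assay on MIA PaCa-2 cells (Homo sapiens) for inhibition, read by MTT assay, with a stated time of 72 h, tested at 30 uM (a higher number here means more inhibition of growth at the concentration tested, a lower number less inhibition of growth), compound 1 gives 39.6%, and compound 2 gives 40.1%. Compound 2 holds the highest of the two numbers, but its nearest neighbour, compound 1, lies within the scatter of it, so the two cannot be ranked against each other.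

Compound 3 `C=CCc1ccc(OCc2cn(-c3ccc(Br)cc3)nn2)c(O)c1` is the next candidate. It differs from compound 2 by bromo in place of benzoyl on an aromatic carbon. For the measured compounds named here, no step between measured compounds is available, so nothing calibrates the effect of changing this position. The two measured compounds carry quite different groups on that ring yet give numbers within the scatter, which argues for a small step; the expected step of a number 2.1 percentage points lower from compound 2 to compound 3 (within the scatter) is therefore none beyond the scatter. Compound 3 is estimated to give 38%, within a range from 24% to 52%.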

Compound 3, percent growth inhibition at one concentration: 43.3%
For compound 3 the middle estimate is 5.3 percentage points below the measured one; the range from low to high includes it.
By their numbers in this assay, from the lowest: compounds 1, 2 and 3 (each within the scatter of the next).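

Bromo in place of benzoyl on the aromatic carbon, para to a large group, gives a number 3.2 percentage points higher from compound 2 to compound 3 (within the scatter) in this assay and is the first measured step at this position. Losing the benzoyl group's carbon-only aromatic ring and its hydrogen-bond acceptor therefore produces no change beyond the scatter in this comparison. The wider exchange of 4-bromophenyl in place of 2-(hydroxymethyl)phenyl on the aromatic nitrogen gives a number 3.7 percentage points higher from compound 1 to compound 3 (within the scatter) and likewise stays inside that limit, while nothing available explains either result.

On these data alone, what an amine, a carboxylic acid or a longer chain at this place would give in this assay remains open. So does whether any group on this ring can move the number beyond the scatter, since the three compounds shown do not settle how far this position tolerates change.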